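The compounds below may be only part of what the source reports. "The series", "measured", "known", "first", "only" and "open" are said of these compounds alone.

Compound 1 `COc1cccc(CNCCCNc2ccnc3cc(Oc4ccc(Cl)cc4)ccc23)c1O` stands second highest of the three measured compounds in a physicochemical assay for solubility, with a stated time of 18 h, at pH 7.4 (on this read-out higher numbers stand for higher solubility and lower numbers for lower solubility), where compound 1 gives 14500 nM. Compound 2 `COc1cccc(CNCCCNc2ccnc3cc(-c4ccccc4)ccc23)c1O` gives 32000 nM in this assay, and compound 3 `COc1cccc(CNCCCNc2ccnc3cc(Cc4ccc(F)cc4)ccc23)c1O` gives 4200 nM. Every measured step changes the group on an aromatic carbon of the shared core: a 2.2-fold higher number from compound 1 to compound 2 (0.34 log units; beyond the scatter), a 3.5-fold lower number from compound 1 to compound 3 (0.54 log units; beyond the scatter) and a 7.6-fold lower number from compound 2 to compound 3 (0.88 log units; beyond the scatter). Compound 4 `Clc1ccc(Oc2ccc3c(NCCCNCc4ccco4)ccnc3c2)cc1` differs from compound 1 at a different place: furan-2-yl in place of 2-hydroxy-3-methoxyphenyl on a saturated chain carbon bound to an amine nitrogen. Among the measured compounds shown here, no measured step touches this place, so none of them bears directly on the change, and no step beyond the scatter is expected in either direction. Compound 4 is therefore expected to give about 12000 nM, between 4000 nM and 40000 nM, an estimated 1.2-fold lower number from compound 1 to compound 4 (0.08 log units; within the scatter).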

Compound 4, solubility: 14500 nM
For compound 4 the middle estimate is 1.2-fold (0.08 log units) below the measured one; low and high end bracket the measured number.
By their numbers in this assay, from the lowest: compound 3; then compounds 1 and 4 (each within the scatter of the next); then compound 2.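

The swap of 2-hydroxy-3-methoxyphenyl for furan-2-yl is the first change shown on a saturated chain carbon bound to an amine nitrogen, and in this assay it gives no change at the digits printed from compound 1 to compound 4 (within the scatter). The entering group has fewer heavy atoms and no hydrogen-bond donor, yet the number stays within the scatter. No measurement shown here explains this result. Still open, going by these compounds, is whether a carboxylic acid or a longer chain at this place would shift the number. Also open, on these data alone, is whether this swap would give the same result alongside the phenyl of compound 2.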